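The compounds below may be only part of what the source reports. "The series", "measured", "known", "first", "only" and "open" are said of these compounds alone.

Of the compounds shown here, two have been measured in an assay on CHO cells for displacement of a labelled ligand from D(4) dopamine receptor (Homo sapiens); on this read-out lower numbers stand for stronger inhibition and higher numbers for weaker inhibition. Compound 1 `COc1c(-c2nc(CNC[C@@H]3CCN(Cc4ccccc4)C3)co2)cc(Br)c2ccccc12` gives 15500 nM in this assay. Compound 2 `Oc1ccc(Br)cc1-c1nc(CN2CCN(c3ccccc3)CC2)co1` gives 580 nM in this assay, the lower of the two numbers, and its gap to compound 1 lies beyond the scatter. Compound 3 `COc1ccc(Br)cc1-c1nc(CN2CCN(c3ccccc3)CC2)co1` has not yet been measured. It differs from compound 2 in one place: methyl in place of hydrogen on an oxygen on an aromatic ring, which turns the hydroxy of the 5-bromo-2-hydroxyphenyl into a methoxy. Going by the values given here, no measured pair in this set shows this particular change, so its effect cannot be read from the data; the only methoxy compound, compound 1, also differs in its core and amine, and its number says nothing about the methyl alone. The step from compound 2 to compound 3 is expected to be a modest loss, a 2.6-fold higher number from compound 2 to compound 3 (0.41 log units; beyond the scatter), in the direction of a higher number. Compound 3 is therefore estimated at 1500 nM in this assay, with a range from 400 nM to 6000 nM.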

Compound 3, inhibition constant: 370 nM
Compound 3: the middle estimate sits 4.1-fold (0.61 log units) above what was measured; measured number below the stated range.
By their numbers in this assay, from the lowest: compounds 3 and 2 (each within the scatter of the next); then compound 1.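

In this assay, going by these compounds alone, the change of methyl in place of hydrogen on an oxygen on an aromatic ring gives a 1.6-fold lower number from compound 2 to compound 3 (0.20 log units; within the scatter) and so offers the first direct reading of hydroxy to methoxy in this set. With the rest of the molecule held fixed, the 5-bromo-2-hydroxyphenyl and 5-bromo-2-methoxyphenyl compounds cannot be told apart on this read-out, so the hydrogen on this oxygen can be replaced by methyl without a change that lies beyond the scatter. Nothing at hand explains this result.

From the compounds shown here alone, it remains open whether a larger group on this oxygen, such as ethoxy or a longer chain, would leave the number equally undisturbed. Going by these compounds, it is also open whether hydroxy in place of the methoxy of compound 1 would give a similar result with that compound's different core and amine.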